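Dropping a single fluorine from an ester side chain

This account rests on a few compounds, and the source may have more. Where it says the series, first, only, none or still open, it means among the compounds named here.

Of the compounds shown here, two have been measured in a physicochemical assay for lipophilicity, read by NMR (on this read-out lower numbers stand for lower lipophilicity and higher numbers for higher lipophilicity), so far. Compound 1 `CC(=O)N1CCC[C@H]1C(=O)OCCF` gives -0.43 in this assay, the lower of the two numbers; compound 2 `OCCC(F)(F)CC(F)(F)F` gives 1.12, a clearly higher reading. Compound 3 `CCOC(=O)[C@@H]1CCCN1C(C)=O` shares the core of compound 1 and differs from it in one place only: hydrogen in place of fluoro on a saturated chain carbon, two bonds along the chain from an oxygen next to a carbonyl group. For compound 3 the expected step in this assay is a number 0.13 log units higher from compound 1 to compound 3 (within the scatter), a small rise that stays within the usual scatter. Compound 3 is therefore estimated at -0.3, with a likely range from -0.7 to 0.1.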

Compound 3, partition coefficient: 0
For compound 3 the middle estimate is 0.30 log units below the measured one; the measured number falls inside the stated range.
By their numbers in this assay, from the lowest: compound 1; then compound 3; then compound 2.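

In this assay the change from 2-fluoroethoxy to ethoxy gives a number 0.43 log units higher from compound 1 to compound 3 (beyond the scatter) on the shared core, so removing one fluorine at this position produces a real step, not just noise. Among these compounds, this is the first single-place comparison available here, since compound 2 shares no such link with compound 1. No measured evidence explains the size of this step. Going by these compounds, what a hydroxyl group, an amine or a longer chain would do at this position stays open. One pair also cannot show whether the same swap gives a similar step on a different core.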